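From chloro to acetamido: one swap, one open number

This account rests on a few compounds, and the source may have more. Where it says the series, first, only, none or still open, it means among the compounds named here.

Going by the values given here, in a functional assay on QGY-7703 cells (Homo sapiens) for cytotoxicity, read by MTT assay, with a stated time of 24 h (on this read-out lower numbers stand for stronger inhibition and higher numbers for weaker inhibition), compound 2 (`O=C1/C(=C/c2cccnc2)CN(S(=O)(=O)c2ccc(Cl)cc2)C/C1=C\c1ccccc1C(F)(F)F`) gives 3440 nM, the lower of the two numbers so far. Compound 1 (`CC(=O)Nc1ccc(S(=O)(=O)N2C/C(=C\c3cccnc3)C(=O)/C(=C/c3ccccc3F)C2)cc1`) gives 9640 nM. The gap between these two compounds lies beyond the scatter. Compound 3 (`CC(=O)Nc1ccc(S(=O)(=O)N2C/C(=C\c3cccnc3)C(=O)/C(=C/c3ccccc3C(F)(F)F)C2)cc1`) differs from compound 2 in one place: acetamido in place of chloro on an aromatic carbon. Among the compounds with values here, no measured pair isolates this change. Compound 1 also carries acetamido and reads 9640 nM, so a small rise in this assay, roughly the size of the scatter, is expected. The expected step is a 1.7-fold higher number from compound 2 to compound 3 (0.24 log units; within the scatter). For compound 3 the estimate is 6000 nM, with an expected range of 2500 nM to 13000 nM.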

Compound 3, half-maximal inhibitory concentration: 5380 nM
The estimate for compound 3 lay 1.1-fold (0.05 log units) above the measured number, and the stated range covers the measured number.
By their numbers in this assay, from the lowest: compounds 2, 3 and 1 (each within the scatter of the next, the first and the last beyond it).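

In this assay acetamido in place of chloro now has a comparison that changes only one place, and it gives a 1.6-fold higher number from compound 2 to compound 3 (0.19 log units; within the scatter) and so does not separate the two groups. Trifluoromethyl in place of fluoro on an aromatic carbon, a second single change, gives a 1.8-fold lower number from compound 1 to compound 3 (0.25 log units; within the scatter) and likewise separates nothing. No measurement shown accounts for either step.

Going by these compounds, whether an amine or a carboxylic acid in the place of chloro, para to a large group, would move the number beyond the scatter remains open.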